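Methylamino to Methoxy on a Deazapurine Nucleoside

A few compounds are considered here, and "the series" means these few. Any claim that something is new, unique, unknown or untested is made for them only; others in the source may bear on it.

Compound 1: `COc1ncnc2c1c(-c1ccoc1)cn2[C@@H]1O[C@H](CO)[C@@H](O)[C@H]1O` — 110 nM
Compound 2: `C#Cc1cn([C@@H]2O[C@H](CO)[C@@H](O)[C@H]2O)c2ncnc(NC)c12` — > 20000 nM

Two compounds share a nucleoside core and were tested in a functional assay on CCRF-CEM cells (Homo sapiens), read by MTT assay, with a stated time of 72 h; a higher number here means a weaker inhibitor, a lower number a stronger inhibitor. Compound 1 gives 110 nM. From the compounds shown here alone, for compound 2 the assay reports only a limit, > 20000 nM, so its true value is unknown; it stands at the limit of > 20000 nM in this assay, at which 1 of the 2 values shown sits. Within the data shown here, no single-point step between the two measured compounds is available, and both the carbon substituent on the five-membered ring and the group on the six-membered ring differ between them.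

Compound 3, `C#Cc1cn([C@@H]2O[C@H](CO)[C@@H](O)[C@H]2O)c2ncnc(OC)c12`, is not yet measured. It differs from compound 2 by methoxy in place of methylamino on an aromatic carbon. Since compound 2 gives only a limit, the expected step of an at least 6.6-fold lower number from compound 2 to compound 3 (0.82 log units; beyond the scatter) in this assay is highly uncertain; compound 1 shows that a methoxy-bearing analogue of this core can be potent, but its other substituent also differs. Compound 3 is therefore estimated at 3000 nM, within 300 nM to 20000 nM.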

Compound 3, half-maximal inhibitory concentration: > 20000 nM
Compound 3: no number, only a limit (the forecaster's own chance of this, stated with the estimate: 35%); middle value at least 6.6-fold (0.82 log units) from the limit.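

Replacing methylamino with methoxy did not bring the ethynyl compound into a measurable range: in this assay, compound 3 gives > 20000 nM, which is a limit and not a number. Compound 1 and compound 3 both carry methoxy and differ in one place, and ethynyl in place of furan-3-yl gives an at least 180-fold higher number from compound 1 to compound 3 (2.25 log units; beyond the scatter), so methoxy alone does not confer potency on the shared core. The step from methylamino to methoxy itself cannot be read, with both of its ends resting on the same limit: the limit of > 20000 nM in this assay, at which 2 of the 3 values shown sit.

From the compounds shown here alone, whether methoxy and methylamino differ at all with ethynyl present therefore stays open. Also open, going by these compounds, is whether methylamino would hold up alongside furan-3-yl, and whether a phenyl or thiophen-3-yl group on that carbon would behave like furan-3-yl.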